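From chloro to nitro: working notes on compound 4

A few compounds are considered here, and "the series" means these few. Any claim that something is new, unique, unknown or untested is made for them only; others in the source may bear on it.

Compound 1 `COc1cc(OC)c(OC)cc1/C=C/C(=O)c1ccc(Cl)cc1`: 29500 nM
Compound 2 `COc1cc(OC)c(-c2cc(=O)c3ccc(O)cc3o2)cc1OC`: > 150000 nM (a limit, not a number)
Compound 3 `COc1cc(OC)c(C(=O)/C=C/c2cc(OC)c(OC)cc2OC)c(OC)c1`: 51400 nM

All three values come from a functional assay on MCF7 cells (Homo sapiens) for inhibition, read by MTT assay, with a stated time of 72 h; a higher number here means a weaker inhibitor, a lower number a stronger inhibitor. Only compound 1 and compound 3 give numbers, and these two lie within the usual scatter of each other, so neither can be ranked ahead of the other. The reading for compound 2 is a limit of this assay.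

The next compound to be measured is compound 4 `COc1cc(OC)c(OC)cc1/C=C/C(=O)c1ccc([N+](=O)[O-])cc1`. It keeps the core of compound 1 and changes one place: nitro in place of chloro on an aromatic carbon, para to a large group (nitro in place of chloro on an aromatic carbon).

Going by the values given here, no measured pair in this small set differs in one place only, so the data offer no direct guide to the size of this step. The working expectation in this assay is therefore no change beyond the scatter, anchored on compound 1 at 29500 nM, with wide uncertainty in either direction. The expected step is a 1.2-fold lower number from compound 1 to compound 4 (0.07 log units; within the scatter). For compound 4 the estimated value is 25000 nM, with an expected range of 8000 nM to 80000 nM.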

Compound 4, half-maximal inhibitory concentration: > 150000 nM
Compound 4 was reported as a limit; the forecaster's own chance of this, stated with the estimate: 5%; at least 6.0-fold (0.77 log units) between middle value and limit.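

In this assay, going by these compounds alone, nitro in place of chloro on an aromatic carbon, para to a large group, gives the first one-place step, and that step is not silent: it is an at least 5.0-fold higher number from compound 1 to compound 4 (0.70 log units; beyond the scatter). Compound 4 gives > 150000 nM, which is a limit of the assay and not a number. This position therefore responds to the group it carries, something the earlier compounds could not show, but the step is only a lower bound and its full size cannot be read because the reading for compound 4 is a limit: the limit of > 150000 nM in this assay, at which 2 of the 4 values shown sit.

Chloro and nitro are the only groups shown at this position, so it remains open whether an amine or a carboxylic acid there would give a value close to that of compound 1 or another limit. Compound 2 and compound 3 differ from compound 1 in more than one place, so they cannot show whether the nitro step would carry over to another core.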